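Fluoro for chloro in a valine benzylamide

A few compounds are considered here, and "the series" means these few. Any claim that something is new, unique, unknown or untested is made for them only; others in the source may bear on it.

Measured so far:
- compound 1, `CC(C)[C@@H](N)C(=O)NCc1ccc(Cl)cc1`: "not determined" (no result reported)
- compound 2, `CC(C)(C)[C@@H](N)C(=O)NCc1ccc(OCc2cccc(F)c2)cc1`: > 30 mg/kg

Two compounds share an amino acid amide core joined to a benzyl group. In a functional assay on the whole organism (strain albino Sprague-Dawley) with Rattus norvegicus as the target, in the maximal electroshock model (a higher number here means that more compound is needed for the effect, a lower number that less compound is needed), compound 1, with the structure `CC(C)[C@@H](N)C(=O)NCc1ccc(Cl)cc1`, has a result recorded only as "not determined" (no result reported), so no dose stands against it. Compound 2, with the structure `CC(C)(C)[C@@H](N)C(=O)NCc1ccc(OCc2cccc(F)c2)cc1`, gives in this assay > 30 mg/kg, which is a limit of the assay and not a number. That limit is the one point of reference here: the limit of > 30 mg/kg in this assay, at which 1 of the 2 values shown sits. Compound 1 therefore stands nowhere on the scale; neither a number nor a limit is known for it.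

The unmeasured compound 3, `CC(C)[C@@H](N)C(=O)NCc1ccc(F)cc1`, differs from compound 1 in a single place: fluoro in place of chloro on an aromatic carbon. With no dose for compound 1, the size of the step to compound 3 in this assay cannot be anchored; the exchange of one halogen for another on the same aromatic carbon is expected to move the dose, if at all, by no more than the usual scatter, in no sure direction. Compound 3 is therefore estimated to need about 40 mg/kg, in a range from 10 mg/kg to 150 mg/kg, with a real chance that only a limit is reported.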

Compound 3, dose for half-maximal effect: 21 mg/kg
Compound 3: middle estimate off by 1.9-fold (0.28 log units), on the high side; low and high end bracket the measured number.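

Going by these compounds alone, compound 1 has no dose to compare, so the exchange of chloro for fluoro that leads to compound 3 gives no step that can be read. Nothing shown here explains the result for compound 3. Still open, from the compounds shown here alone, is whether the choice between these two halogens on the aromatic carbon changes the dose needed in this assay at all.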